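The compounds below may be only part of what the source reports. "The series", "measured", "known", "first", "only" and "open" are said of these compounds alone.

Compound 1 `Oc1cccc(-c2cc(-c3ccccc3O)cc(-c3ccccc3O)n2)c1` gives 730 nM in an ADME assay on HEK293 cells (Homo sapiens) for cytotoxicity, read by CCK-8 assay, with a stated time of 4 days; a lower number here means a stronger inhibitor, a higher number a weaker inhibitor. Compound 2 `Oc1cccc(-c2cc(-c3ccccc3O)cc(-c3cccc(O)c3)n2)c1` gives 130 nM in this assay and stands lowest of the two numbers shown, with compound 1 the nearest. Compound 3 `Oc1ccc(-c2cc(-c3cccc(O)c3)cc(-c3ccc(O)cc3)n2)cc1` reaches only a limit of this assay, reported as > 50000 nM, which is the limit of > 50000 nM in this assay, at which 1 of the 3 values shown sits. Compound 4 `Oc1cccc(-c2cc(-c3cccc(O)c3)nc(-c3cccc(O)c3)c2)c1` differs from compound 2 in one place: 3-hydroxyphenyl in place of 2-hydroxyphenyl on an aromatic carbon. The same change has been measured once already: a 5.6-fold lower number from compound 1 to compound 2 (0.75 log units; beyond the scatter), a step beyond the usual scatter. Repeating it is therefore expected to lower the number once more, although compound 2 already sits low and a second step of the same size is less certain. Compound 4 is estimated at 45 nM, between 12 nM and 170 nM, which is expected to be a step of a 2.9-fold lower number from compound 2 to compound 4 (0.46 log units; beyond the scatter).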

Compound 4, half-maximal inhibitory concentration: 740 nM
For compound 4 the middle estimate is 16-fold (1.22 log units) below the measured one; the whole stated range lies below it.
By their numbers in this assay, from the lowest: compound 2; then compounds 1 and 4 (each within the scatter of the next). At a limit, above all of these: compound 3.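

In this assay the swap of 2-hydroxyphenyl for 3-hydroxyphenyl does not act alike in every case: it gave a 5.6-fold lower number from compound 1 to compound 2 (0.75 log units; beyond the scatter), whereas on the carbon opposite the ring nitrogen it gives a 5.7-fold higher number from compound 2 to compound 4 (0.76 log units; beyond the scatter). The result of this change therefore differs with the compound in which it is made, so one step cannot simply be carried over to another. Nothing measured here gives a reason for this reversal. Still open, as far as these compounds go, is how this place responds when an aminophenyl group or a carboxylic acid stands there.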